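Predicting Cytotoxicity After Swapping the Aryl Group on Piperazine

The source may report more compounds than this note shows. Statements on the series, on what has been measured and on what is new or still open speak of the compounds shown alone.

Of the compounds shown here, three sharing one core have been measured in an ADME assay on PNT1A cells (Homo sapiens) for cytotoxicity, read by MTT assay, with a stated time of 48 h; on this read-out higher numbers stand for weaker inhibition and lower numbers for stronger inhibition. Compound 1 `COc1cc(O)ccc1N1CCN(CC(O)COc2ccc(O)c3ccccc23)CC1` gives 37200 nM in this assay, and compound 2 `Oc1ccccc1N1CCN(CC(O)COc2ccc(O)c3ccccc23)CC1` gives 37400 nM, the two being within the scatter of each other (a 1.0-fold higher number from compound 1 to compound 2 (0.00 log units; within the scatter)). Compound 3 `Oc1ccc(N2CCN(CC(O)COc3ccc(O)c4ccccc34)CC2)c(O)c1` gives 17100 nM in this assay, the lowest of the three numbers, with both neighbours beyond the scatter: a 2.2-fold lower number from compound 1 to compound 3 (0.34 log units; beyond the scatter) and a 2.2-fold lower number from compound 2 to compound 3 (0.34 log units; beyond the scatter).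

Compound 4 `COc1ccccc1N1CCN(CC(O)COc2ccc(O)c3ccccc23)CC1` is not yet measured. The change is 2-methoxyphenyl in place of 2,4-dihydroxyphenyl on an amine nitrogen in a ring. Going by the values given here, two measured steps bear on it, each in reverse: compound 3 to compound 2 removed a hydroxy, and compound 3 to compound 1 replaced a hydrogen on an oxygen with methyl, each raising the number about as far as the steps above show. Compound 4 combines both changes, so a modest rise beyond the scatter is expected, a 2.6-fold higher number from compound 3 to compound 4 (0.42 log units; beyond the scatter), and the estimated value for compound 4 in this assay is 45000 nM, within a range from 22000 nM to 90000 nM.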

Compound 4, half-maximal inhibitory concentration: 34900 nM
Beside the measured number, compound 4's estimate is 1.3-fold (0.11 log units) above it; the measured number falls inside the stated range.
By their numbers in this assay, from the lowest: compound 3; then compounds 4, 1 and 2 (each within the scatter of the next).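

In this assay, the two changes do not stack: the full swap gives a 2.0-fold higher number from compound 3 to compound 4 (0.31 log units; beyond the scatter), while adding either change to a compound that already carries the other stays small, with a 1.1-fold lower number from compound 2 to compound 4 (0.03 log units; within the scatter) and a 1.1-fold lower number from compound 1 to compound 4 (0.03 log units; within the scatter), so among these four compounds only compound 3, with its 2,4-dihydroxyphenyl on the ring nitrogen, stands apart. Replacing methyl with hydrogen on the oxygen moved the number beyond the scatter on one core and within it on the other, but this gap is not firm: the same change on two cores in this assay, a 2.2-fold lower number (0.34 log units; beyond the scatter) from compound 1 to compound 3 and a 1.1-fold higher number (0.03 log units; within the scatter) from compound 4 to compound 2, 2.3-fold (0.37 log units) apart, within the scatter of two such steps. The same caution applies to adding the hydroxy: the same change on two cores in this assay, a 2.2-fold lower number (0.34 log units; beyond the scatter) from compound 2 to compound 3 and a 1.1-fold higher number (0.03 log units; within the scatter) from compound 4 to compound 1, 2.3-fold (0.37 log units) apart, within the scatter of two such steps.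

The compounds shown leave open whether compound 3's lower number needs both hydroxy groups on the aromatic ring. They also leave open whether an amine or a carboxylic acid on that ring would give a similar number.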